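Ethoxy in place of methoxy on an aryl ether

The compounds below may be only part of what the source reports. "The series", "measured", "known", "first", "only" and "open" are said of these compounds alone.

Measured compounds:
compound 1, `CCOc1c(-c2occ(C)c2C(=O)OC)ccc2c(CC)cccc12`, 2.4 ug/mL
compound 2, `CCc1cccc2c(OC)c(-c3occ(C)c3COC)ccc12`, > 10 ug/mL

Of the compounds shown here, two with a shared core have been tested in a functional assay on A549 cells (Homo sapiens) for cytotoxicity, read by MTT assay, with a stated time of 72 h; on this read-out higher numbers stand for an effect only at larger amounts of compound and lower numbers for an effect already at smaller amounts. Compound 1, `CCOc1c(-c2occ(C)c2C(=O)OC)ccc2c(CC)cccc12`, gives 2.4 ug/mL. Compound 2, `CCc1cccc2c(OC)c(-c3occ(C)c3COC)ccc12`, gives only a limit of the assay, > 10 ug/mL, so no number is known for it. Compound 2 therefore stands at the limit of > 10 ug/mL in this assay, at which 1 of the 2 values shown sits, with compound 1 the only one of the two that gives a value. Within the data shown here, compound 1 and compound 2 differ in more than one place, so their two values show only that one gives a number and the other a limit.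

Compound 3, `CCOc1c(-c2occ(C)c2COC)ccc2c(CC)cccc12`, is not yet measured. It differs from compound 2 by methyl in place of hydrogen on a saturated chain carbon bound to an oxygen on an aromatic ring. Among the measured compounds shown here, no step between measured compounds has been computed, so the size of this change cannot be read from the data. My expectation is a modest move toward an effect at smaller amounts, or none beyond the scatter, which as a step of an at least 1.2-fold lower number from compound 2 to compound 3 (0.09 log units; that floor lies within the scatter) is only an estimate. For compound 3 I therefore expect 8 ug/mL, within 3 ug/mL to 25 ug/mL.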

Compound 3, concentration for half-maximal effect: > 10 ug/mL
Compound 3 ended at the assay's limit (the forecaster's own chance of this, stated with the estimate: 45%); middle value at least 1.2-fold (0.09 log units) from the limit.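

In this assay compound 3 gives > 10 ug/mL, which is a limit of the assay and not a number. Among these compounds, the step from methoxy to ethoxy cannot be read, because compound 2 and compound 3 both end at the same limit, so neither has a number to compare: the limit of > 10 ug/mL in this assay, at which 2 of the 3 values shown sit. The new information lies in the other comparison, the first here between two compounds that differ in one place: with the ethoxy group kept, methoxymethyl in place of methoxycarbonyl on an aromatic carbon gives an at least 4.1-fold higher number from compound 1 to compound 3 (0.61 log units; beyond the scatter), which shows that the group at this aromatic carbon matters in this assay and that the methoxycarbonyl form is the one that gives a measurable effect.

The compounds shown leave open how much weaker compound 2 and compound 3 really are, and whether swapping methoxy for ethoxy changes anything when the methoxycarbonyl group is present. They also leave open whether a carboxylic acid or a primary amide at the same aromatic carbon would retain the effect seen with methoxycarbonyl.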